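A Methoxy Step Repeated Across Two Related Cores

The compounds below may be only part of what the source reports. "The series", "measured", "known", "first", "only" and "open" are said of these compounds alone.

Of the compounds shown here, three have so far been tested in a functional assay on T-24 cells (Homo sapiens) for cytotoxicity, read by colorimetric assay and MTT assay; on this read-out higher numbers stand for weaker inhibition and lower numbers for stronger inhibition. Compound 1 `COc1ccc2cc(-c3ccccc3)c(O)nc2c1` gives 10000 nM in this assay. Compound 2 `COc1cc(OC)c2cc(-c3ccccc3)c(O)nc2c1` differs from it by one group, (methoxy in place of hydrogen on an aromatic carbon), and in this assay compound 2 gives 10000 nM. The resulting step is no change at the digits printed from compound 1 to compound 2 (within the scatter). Compound 3 `COc1ccc(-c2cc3cccc(OC)c3nc2O)cc1` gives 10000 nM in this assay, level with compounds 1 and 2 within the scatter; the difference between the core of compound 1 and the core of compound 3 is not broken down here.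

Compound 4 `COc1ccc(-c2cc3c(OC)ccc(OC)c3nc2O)cc1` has not been measured. It arises from compound 3 through (methoxy in place of hydrogen on an aromatic carbon). Going by the values given here, this is the same kind of change as the one from compound 1 to compound 2, though the surroundings differ: in compound 2 the entering group sits meta to a methoxy group, in compound 4 para to a methoxy group. Because the earlier step of no change at the digits printed from compound 1 to compound 2 (within the scatter) left the value unchanged, compound 4 is expected to follow, with an estimated step of no change at the digits printed from compound 3 to compound 4 (within the scatter) in this assay. Compound 4 is therefore estimated at 10000 nM, expected to fall between 5000 nM and 20000 nM.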

Compound 4, half-maximal inhibitory concentration: 10000 nM
Compound 4: middle estimate and measured number agree at the digits printed; the range from low to high includes it.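

Carried onto the core of compound 3, methoxy in place of hydrogen on an aromatic carbon gives no change at the digits printed from compound 3 to compound 4 (within the scatter) in this assay. Set beside the step on the core of compound 1, the change carries over between these two cores with no difference between the steps: the same change on two cores in this assay, no change at the digits printed (within the scatter) from compound 1 to compound 2 and no change at the digits printed (within the scatter) from compound 3 to compound 4, 1.0-fold (0.00 log units) apart, within the scatter of two such steps. Going by these compounds alone, this shows only that the change left the value untouched on both cores, with compound 4 at 10000 nM and level with the other three compounds; it does not show how the change would behave on a compound with a different value, and two pairs set no rule for the wider series.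

As far as these compounds go, what an amine, a carboxylic acid or a chlorine atom would do on the same aromatic carbon remains open, as does a longer chain such as butoxy in place of methoxy. Also open is whether any substituent on these two cores moves the value at all, as all four compounds shown read alike.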